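Urea to amide: a change at the carbonyl of compound 2

The source may report more compounds than this note shows. Statements on the series, on what has been measured and on what is new or still open speak of the compounds shown alone.

Measured compounds in a functional assay on A549 cells (Homo sapiens) for inhibition, read by sulforhodamine B assay, with a stated time of 48 h, tested at 1 uM; a higher number here means a weaker effect of the compound at the concentration tested, a lower number a stronger effect:
- compound 1, `O=C(Nc1cccc(-n2cc(-c3ccncc3)c(-c3cc(O)cc(Cl)c3)n2)c1)Nc1ccc(Cl)c(C(F)(F)F)c1`, gives 81%
- compound 2, `COc1cc(Cl)cc(-c2nn(-c3cccc(NC(=O)Nc4ccc(Cl)c(C(F)(F)F)c4)c3)cc2-c2ccncc2)c1`, gives 40%
- compound 3, `COc1cc(Cl)cc(-c2nn(-c3cccc(NC(=O)Nc4cc(C(F)(F)F)cc(C(F)(F)F)c4)c3)cc2-c2ccncc2)c1`, gives 15%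

Compound 2 sits second highest of the three numbers in this assay. Its nearest neighbour is compound 3, whose value lies below it beyond the scatter, and its furthest is compound 1, whose value lies above it beyond the scatter. Among the compounds with values here, the one measured step, a number 41 percentage points lower from compound 1 to compound 2 (beyond the scatter), concerns a methyl placed on an oxygen and says nothing about the amide end of the molecule.

Compound 4, `COc1cc(Cl)cc(-c2nn(-c3cccc(NC(=O)c4cccc(C(F)(F)F)c4)c3)cc2-c2ccncc2)c1`, is the compound not yet measured. It differs from compound 2 as follows: 3-(trifluoromethyl)phenyl in place of (4-chloro-3-(trifluoromethyl)phenyl)amino on a carbonyl carbon. Here the hydrogen-bond donor of the leaving group and its chlorine are lost together, and the carbonyl becomes part of a plain amide rather than a urea. Within the data shown here, no measured step covers such a change, so the expectation rests only on the spread of the three values. Compounds 2 and 3 show that altering the group on this carbonyl can move the read-out well beyond the scatter, but in which direction the present change acts is not settled by any shown step.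

The estimate for compound 4 in this assay is 55%, expected to lie between 25% and 85%, which means an expected step of a number 15 percentage points higher from compound 2 to compound 4 (beyond the scatter).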

Compound 4, a percentage reported as activity, at one concentration (the size of the read-out at that concentration, not a potency): 75%
Beside the measured number, compound 4's estimate is 20 percentage points below it, within the range that was stated.
By their numbers in this assay, from the lowest: compound 3; then compound 2; then compounds 4 and 1 (each within the scatter of the next).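

In this assay, replacing (4-chloro-3-(trifluoromethyl)phenyl)amino with 3-(trifluoromethyl)phenyl on the carbonyl carbon, which turns the urea into an amide, gives a number 35 percentage points higher from compound 2 to compound 4 (beyond the scatter). Within the data shown here, this is the first step measured at this end of the molecule, and it shows that this change weakens the effect at the concentration tested, with the urea of compound 2 giving the stronger effect of the pair. No measurement shown here explains the shift.

The step removes the amino nitrogen, with its hydrogen-bond donor, and the chlorine together, so compound 2 and compound 4 cannot show which loss matters, or whether both do. As far as these compounds go, compounds carrying 4-chloro-3-(trifluoromethyl)phenyl directly on the carbonyl carbon, or a methylene or an oxygen in place of the amino nitrogen, would be needed to separate these contributions, and how such groups would behave remains open.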